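The source may report more compounds than this note shows. Statements on the series, on what has been measured and on what is new or still open speak of the compounds shown alone.

Working notes on the series. Compound 3 `Cc1cc(C)n(CCOC2CC(=O)Nc3c2c(C)nn3-c2ncnc3nc[nH]c23)n1` gives 2000 nM in a functional assay on HEK293 cells for agonist activity at G-protein coupled receptor 39 (Homo sapiens), read by scintillation proximity assay and inositol phosphate accumulation, with a stated time of 75 min (a lower number here means that less compound is needed, a higher number that more compound is needed for the effect), the highest number of the three measured compounds. Compound 1 `Cc1nn(-c2ncnc3nc[nH]c23)c2c1C(OCc1ccc(Cl)cc1Cl)CC(=O)N2` gives 243 nM in this assay, and compound 2 `Cc1nn(-c2ncnc3nc[nH]c23)c2c1C(OCc1ccccc1F)CC(=O)N2` gives 78 nM. The steps among them are a 3.1-fold lower number from compound 1 to compound 2 (0.49 log units; beyond the scatter), an 8.2-fold higher number from compound 1 to compound 3 (0.92 log units; beyond the scatter) and a 26-fold higher number from compound 2 to compound 3 (1.41 log units; beyond the scatter).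

Compound 4 `Cc1nn(-c2ncnc3nc[nH]c23)c2c1C(C(=O)NCc1ccccc1)CC(=O)N2` has not been measured. Its difference from compound 3 is a group of 10 heavy atoms (8 carbon, 1 nitrogen, 1 oxygen; one six-membered aromatic ring of carbon only) in place of a group of 10 heavy atoms (7 carbon, 2 nitrogen, 1 oxygen; one five-membered aromatic ring with 2 hetero atoms), on a saturated ring carbon; the oxygen-linked chain carrying the pyrazole is gone and a benzylcarbamoyl takes its place on the same ring carbon. Among the compounds with values here, none of the measured steps is this change: all three swap the group at the end of the oxygen-linked chain, and none exchanges that chain for an amide. What they do show is that a six-membered aromatic carbon ring at that position goes with lower numbers than the pyrazolylmethyl, as in a 26-fold higher number from compound 2 to compound 3 (1.41 log units; beyond the scatter) and an 8.2-fold higher number from compound 1 to compound 3 (0.92 log units; beyond the scatter). Compound 4 brings a carbon-only aromatic ring back, though through a different linkage. On that basis a lower number is expected for compound 4, with the step taken as a 5.0-fold lower number from compound 3 to compound 4 (0.70 log units; beyond the scatter), and the linkage change leaves it uncertain. The estimate for compound 4 in this assay is 400 nM, with a range from 60 nM to 3000 nM.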

Compound 4, half-maximal effective concentration: 2930 nM
Compound 4: middle estimate off by 7.3-fold (0.86 log units), on the low side; the range from low to high includes it.
By their numbers in this assay, from the lowest: compound 2; then compound 1; then compounds 3 and 4 (each within the scatter of the next).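

In this assay, a carbon-only aromatic ring on the saturated ring carbon does not by itself go with a lower number: the exchange of the oxygen-linked pyrazole chain for benzylcarbamoyl gives a 1.5-fold higher number from compound 3 to compound 4 (0.17 log units; within the scatter), so compound 3 and compound 4 cannot be told apart. Set against the oxygen-linked benzyl groups, benzylcarbamoyl gives a 38-fold higher number from compound 2 to compound 4 (1.57 log units; beyond the scatter) and a 12-fold higher number from compound 1 to compound 4 (1.08 log units; beyond the scatter), which confines the link between a six-membered aromatic carbon ring and lower numbers to compound 1 and compound 2, with compound 4 going against it. No measurement in hand bears on the reason for this difference.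

Still open, on these data alone, is how much of these steps belongs to the amide linkage and how much to the substituents on the ring, since an unsubstituted benzyloxy or a (2-fluorobenzyl)carbamoyl on the same ring carbon would compare the two linkages with the same ring at the end. Also open, as far as these compounds go, is whether a longer chain, such as phenethylcarbamoyl, or an amine in place of the amide would behave like benzylcarbamoyl or like the benzyloxy groups.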